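This account rests on a few compounds, and the source may have more. Where it says the series, first, only, none or still open, it means among the compounds named here.

Measured compounds:
Compound 1 `C[Se]c1nc(N)c2ccccc2n1`: 88700 nM
Compound 2 `CCCCC[Se]c1nc([Se]CCCCC)c2cccnc2n1`: 60500 nM
Compound 3 `CSc1nc(NCCCc2ccccc2)c2ccccc2n1`: > 100000 nM, which is a limit of the assay and not a number.

All three were tested in a functional assay on HTB-54 cells (Homo sapiens) for cytotoxicity, read by MTT assay, with a stated time of 72 h; a lower number here means a stronger inhibitor of growth, a higher number a weaker inhibitor of growth. Of the two plain numbers, compound 2 has the lower one, but the gap to compound 1 is within the usual scatter, so the two cannot be told apart. Compound 4 `CCCCC[Se]c1nc(N)c2cccnc2n1` has not been measured. It differs from compound 2 in one place: one nitrogen atom in place of a group of 6 heavy atoms (5 carbon, 1 selenium; no ring), on an aromatic carbon. Within the data shown here, no measured pair shows this change directly. Compound 1 also carries an amino group on its shared core and gives 88700 nM, so no step beyond the scatter is expected here. Compound 4 is estimated at 75000 nM, with a range from 30000 nM to 150000 nM. That estimate corresponds to an expected step of a 1.2-fold higher number from compound 2 to compound 4 (0.09 log units; within the scatter), within the scatter.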

Compound 4, concentration for total growth inhibition: 51000 nM
Compound 4: the middle estimate sits 1.5-fold (0.17 log units) above what was measured, and the stated range covers the measured number.
By their numbers in this assay, from the lowest: compounds 4, 2 and 1 (each within the scatter of the next). At a limit, above all of these: compound 3.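

Replacing the group of 6 heavy atoms (5 carbon, 1 selenium) with amino on this aromatic carbon gives a 1.2-fold lower number from compound 2 to compound 4 (0.07 log units; within the scatter) in this assay. Among these compounds, no earlier pair showed this change, and here the large group can go without a change beyond the scatter, so a single amino does as well at this position on this core. All the numbers lie close to the top of what this assay can read: the limit of > 100000 nM in this assay, at which 1 of the 4 values shown sits.

Still open, going by these compounds, is whether a different group at this position, such as a carboxylic acid or a longer chain, would shift the number beyond the scatter.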